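Extending the amine at the end of a hexyl chain

The compounds below may be only part of what the source reports. "The series", "measured", "known", "first", "only" and "open" are said of these compounds alone.

For the measured compounds named here, compound 2, `COc1cc(/C=C/C(=O)Nc2ccccc2)ccc1OCCCCCCN(C)C`, is the more lipophilic-looking of the two compounds measured so far in a physicochemical assay for lipophilicity, using the shake flask method, measured as octanol-water partition, at pH 7.4 (a higher number here means a more lipophilic compound, a lower number a more polar compound), where compound 2 gives 1.69. Compound 1, `COc1cc(/C=C/C(=O)Nc2ccccc2)ccc1OCCCN1CCCCC1`, gives 1.58 in this assay, and the step of a number 0.11 log units higher from compound 1 to compound 2 (within the scatter) shows the two to lie within the scatter of each other. Compound 3, `COc1cc(/C=C/C(=O)Nc2ccccc2)ccc1OCCCCCCN1CCCCC1`, has not yet been measured. Its difference from compound 2 is piperidin-1-yl in place of dimethylamino on a saturated chain carbon, six bonds along the chain from an oxygen on an aromatic ring, so that the carbon count of the group on the chain grows while the chain itself keeps its six-atom length. Going by the values given here, the one measured step, from compound 1 to compound 2, swaps the amine and lengthens the chain at the same time and so bears only loosely on this change; no measured step isolates the exchange of dimethylamino for piperidin-1-yl. On the added carbons alone, the step of a number 0.81 log units higher from compound 2 to compound 3 (beyond the scatter) is expected to be clearly upward in this assay. Compound 3 is therefore estimated at 2.5, between 1.9 and 3.1.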

Compound 3, partition coefficient: 1.77
Compound 3: the middle estimate sits 0.73 log units above what was measured; the whole stated range lies above it.
By their numbers in this assay, from the lowest: compounds 1, 2 and 3 (each within the scatter of the next).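

In this assay, the exchange of dimethylamino for piperidin-1-yl on a saturated chain carbon, six bonds along the chain from an oxygen on an aromatic ring, now stands alone, and a number 0.08 log units higher from compound 2 to compound 3 (within the scatter) shows that, at this position and on the hexyl chain, the two amines cannot be told apart in this read-out. For the compounds shown here, with the amine held as piperidin-1-yl, the chain can also be read by itself for the first time: 3-(piperidin-1-yl)propyl in place of piperidin-1-yl gives a number 0.19 log units higher from compound 1 to compound 3 (within the scatter) and so leaves compound 1 and compound 3 equally hard to separate. Nothing available explains why neither change registers on this scale.

The compounds shown leave open whether a morpholine, a primary amine or a carboxylic acid at the end of the hexyl chain would stand apart from these three in this assay or stay with them. They also leave open whether an octyl or decyl chain carrying piperidin-1-yl would move beyond the scatter, or whether these numbers would hold there too.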